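One aryl swap, repeated on a closely related core

The source may hold more compounds than are shown below. What is called first, only, known or untested is meant among the compounds shown, and "the series" means these compounds.

Compound 1 `COc1cc(/C=C/C(=O)C(=Cc2ccc(OC)c(OC)c2)C(=O)/C=C/c2ccc(O)c(OC)c2)ccc1O` and compound 2 `CCOc1cc(C=C(C(=O)/C=C/c2ccc(O)c(OC)c2)C(=O)/C=C/c2ccc(O)c(OC)c2)ccc1O` share a core and differ in a single place: 3-ethoxy-4-hydroxyphenyl in place of 3,4-dimethoxyphenyl on a double-bonded chain carbon bound to a double-bonded chain carbon. In a functional assay, read by spectrophotometry, with a stated time of 5 min (on this read-out lower numbers stand for stronger inhibition and higher numbers for weaker inhibition), compound 1 gives 6760 nM, and in the same assay compound 2 gives 3980 nM. The change made a 1.7-fold lower number from compound 1 to compound 2 (0.23 log units; within the scatter), so the two compounds cannot be told apart with confidence on this read-out.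

Compound 3 `CCOc1cc(/C=C/C(=O)C(=Cc2ccc(OC)c(OC)c2)C(=O)/C=C/c2ccc(O)c(OCC)c2)ccc1O` is built on a different core; the difference between the two cores is not broken down here. In this assay compound 3 gives 11300 nM. That number lies within the scatter of the number for compound 1, while it is beyond the scatter of, and higher than, the number for compound 2.

Compound 4 `CCOc1cc(C=C(C(=O)/C=C/c2ccc(O)c(OCC)c2)C(=O)/C=C/c2ccc(O)c(OCC)c2)ccc1O` has not been measured. It stands to compound 3 as compound 2 stands to compound 1, since the change is the same one, made at the same kind of position: 3-ethoxy-4-hydroxyphenyl in place of 3,4-dimethoxyphenyl on a double-bonded chain carbon bound to a double-bonded chain carbon. Among the compounds shown this change occurs twice in all. Among the compounds with values here, the step from compound 3 to compound 4 is expected to be a 1.7-fold lower number from compound 3 to compound 4 (0.22 log units; within the scatter) in this assay because the only measured example of the change, a 1.7-fold lower number from compound 1 to compound 2 (0.23 log units; within the scatter), stayed within the scatter. Compound 4 is therefore expected to give about 6800 nM in this assay. Compound 4 is estimated to fall between 3000 nM and 15000 nM, the width reflecting that this expectation rests on a single measured pair.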

Compound 4, half-maximal inhibitory concentration: 5140 nM
For compound 4 the middle estimate is 1.3-fold (0.12 log units) above the measured one, and the stated range covers the measured number.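

In this assay, 3-ethoxy-4-hydroxyphenyl in place of 3,4-dimethoxyphenyl gives a 2.2-fold lower number from compound 3 to compound 4 (0.34 log units; beyond the scatter). This is a modest step, and set beside the same change on the other core, it points the same way and does not differ in size by more than repeated measurements would: the same change on two cores in this assay, a 1.7-fold lower number (0.23 log units; within the scatter) from compound 1 to compound 2 and a 2.2-fold lower number (0.34 log units; beyond the scatter) from compound 3 to compound 4, 1.3-fold (0.11 log units) apart, within the scatter of two such steps. Within the data shown here, the change therefore carries over from the core of compound 1 to the core of compound 3 in direction and about in size, but the support is only two pairs, one of them within the scatter, and this neither explains the step nor shows that it would hold on any other core.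

The group that enters differs from the one that leaves in both its ethoxy chain and its hydroxy group, and the compounds shown do not separate the two, so it remains open which of them accounts for the lower numbers. Also open, going by these compounds, is how this position would respond to a longer chain such as propoxy in place of the ethoxy, or to an amine or a carboxylic acid in place of the hydroxy group.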